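This account rests on a few compounds, and the source may have more. Where it says the series, first, only, none or still open, it means among the compounds named here.

Compound 3 `COc1ccc(/C=C/c2cc(OC)cc(OC)c2/C=C/C(=O)N(CC(C)C)CC(C)C)cc1` gives the lowest number of the three measured compounds in a functional assay on A549 cells (Homo sapiens) for inhibition, read by MTT assay, with a stated time of 48 h (on this read-out higher numbers stand for weaker inhibition and lower numbers for stronger inhibition), at 3350 nM. Its nearest neighbour is compound 2 `COc1ccc(/C=C/c2cc(OC)cc(OC)c2/C=C/C(=O)N2CCC(c3ccccc3)CC2)cc1`, which gives 6690 nM, the gap being a 2.0-fold lower number from compound 2 to compound 3 (0.30 log units; within the scatter); compound 1 `CCCCCCCCNC(=O)/C=C/c1c(/C=C/c2ccc(OC)cc2)cc(OC)cc1OC` gives 8660 nM, and the step of a 2.6-fold lower number from compound 1 to compound 3 (0.41 log units; beyond the scatter) is the only one beyond the scatter. Compound 4 `CCCCCCNC(=O)/C=C/c1c(/C=C/c2ccc(OC)cc2)cc(OC)cc1OC` differs from compound 3 in one place: hexylamino in place of diisobutylamino on a carbonyl carbon. The measured step closest to this change is a 2.6-fold lower number from compound 1 to compound 3 (0.41 log units; beyond the scatter) read backwards: compound 1 carries octylamino, a chain bearing one hydrogen-bond donor, as hexylamino does. The step of a 1.3-fold lower number from compound 1 to compound 2 (0.11 log units; within the scatter) adds little. A modest rise in the number is therefore expected for compound 4, a 2.1-fold higher number from compound 3 to compound 4 (0.32 log units; beyond the scatter). The estimated value for compound 4 is 7000 nM, within 3000 nM to 16000 nM.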

Compound 4, half-maximal inhibitory concentration: 6230 nM
The estimate for compound 4 lay 1.1-fold (0.05 log units) above the measured number, and the stated range covers the measured number.
By their numbers in this assay, from the lowest: compounds 3, 4, 2 and 1 (each within the scatter of the next, the first and the last beyond it).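

In this assay, hexylamino in place of diisobutylamino on the carbonyl carbon gives a step within the scatter (a 1.9-fold higher number from compound 3 to compound 4 (0.27 log units; within the scatter)), so adding the amide hydrogen does not clearly separate compound 4 from compound 3. The steps from the 4-phenylpiperidin-1-yl group (a 1.1-fold lower number from compound 2 to compound 4 (0.03 log units; within the scatter)) and from the longer octylamino chain (a 1.4-fold lower number from compound 1 to compound 4 (0.14 log units; within the scatter)) also stay within the scatter, so compound 4 sits amid the series without a clear gap to any member. No measurement here offers an explanation for these small differences.

As far as these compounds go, whether a much shorter chain such as ethylamino, or a carboxylic acid at the end of the hexyl chain, would move the number clearly beyond this narrow band remains open.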